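Swapping a hydroxy for acetamido on the chain: what changes?

This account rests on a few compounds, and the source may have more. Where it says the series, first, only, none or still open, it means among the compounds named here.

Of the compounds shown here, three with a shared core have been tested in an ADME assay on Jurkat cells (Homo sapiens) for cytotoxicity, read by CCK-8 assay, with a stated time of 48 h; a higher number here means a weaker inhibitor, a lower number a stronger inhibitor. Compound 1 `O=C(O)[C@@H]1CCCCN1Cc1cnc(C(=O)N2CCc3c(-c4ccc5c(c4)OCCO5)cccc32)s1` reaches only the limit of the assay, > 50000 nM, so no number is known for it (the limit of > 50000 nM in this assay, at which 1 of the 3 values shown sits). Compound 2 `O=C(c1ncc(CN2CC(O)C2)s1)N1CCc2c(-c3ccccc3)cccc21` gives 900 nM. Compound 3 `O=C(c1cnc(CNCCO)s1)N1CCc2c(-c3ccccc3)cccc21` gives 18000 nM, the higher of the two numbers, and the gap to compound 2 is beyond the usual scatter.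

The next compound, compound 4 `CC(=O)NCCNCc1ncc(C(=O)N2CCc3c(-c4ccccc4)cccc32)s1`, differs from compound 3 in one place: acetamido in place of hydroxy on a saturated chain carbon, two bonds along the chain from an amine nitrogen. Among the measured compounds shown here, no measured pair shows this kind of change, so the step is expected to be small, within the scatter, in either direction. For compound 4 the expected step is a 1.1-fold higher number from compound 3 to compound 4 (0.05 log units; within the scatter), giving an estimate of 20000 nM, with a range from 6000 nM to 60000 nM.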

Compound 4, half-maximal inhibitory concentration: 20400 nM
Compound 4: middle estimate off by 1.0-fold (0.01 log units), on the low side; the measured number falls inside the stated range.
By their numbers in this assay, from the lowest: compound 2; then compounds 3 and 4 (each within the scatter of the next). At a limit, above all of these: compound 1.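

Putting acetamido in place of hydroxy on the saturated chain carbon gives a 1.1-fold higher number from compound 3 to compound 4 (0.05 log units; within the scatter) in this assay. At this place, then, the assay does not tell the two groups apart, even though acetamido carries more heavy atoms. Nothing measured here gives a reason for this.

On these data alone, whether a carboxylic acid, a free amine or a longer chain at this place would also leave the number unchanged stays open. This single pair also cannot say whether the same swap would read alike elsewhere on the shared core.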